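Chloro for methyl on the benzyl ring of a hydroxamic acid

This account rests on a few compounds, and the source may have more. Where it says the series, first, only, none or still open, it means among the compounds named here.

Measured compounds:
- compound 1, `Cc1ccc(CN2CC=C(CCC(=O)NO)C2=O)cc1`: 2500 nM
- compound 2, `O=C(CCC1=CCN(CCCCc2ccc(Cl)cc2)C1=O)NO`: 6250 nM

The two measured compounds share a hydroxamic acid core and were tested in a functional assay on NCI-H23 cells (Homo sapiens) for inhibition, read by sulforhodamine B assay; on this read-out lower numbers stand for stronger inhibition of growth and higher numbers for weaker inhibition of growth. In this assay compound 1 gives 2500 nM, the lowest of the two numbers. Compound 2, which carries a longer chain to a chloro-bearing aromatic ring, gives 6250 nM, a higher number and beyond the usual scatter of this assay, so compound 1 stands as the stronger of the two growth inhibitors.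

The step under consideration leads from compound 1 to compound 3, `O=C(CCC1=CCN(Cc2ccc(Cl)cc2)C1=O)NO`. The difference is chloro in place of methyl on an aromatic carbon. Going by the values given here, no pair of measured compounds differing in a single place is available, so the size of such a change cannot be read from the data; compound 2 differs from compound 3 in the chain length as well and therefore gives no clean guide.

For compound 3 the expectation is a step of no change at the digits printed from compound 1 to compound 3 (within the scatter), that is, no change beyond the scatter of this assay. Compound 3 is accordingly estimated at 2500 nM, with a range from 1000 nM to 6000 nM.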

Compound 3, concentration for 50% growth inhibition: 2500 nM
For compound 3 middle estimate and measured number coincide at the digits printed; the measured number falls inside the stated range.
By their numbers in this assay, from the lowest: compounds 1 and 3 (each within the scatter of the next); then compound 2.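

In this assay, going by these compounds alone, the exchange of methyl for chloro on an aromatic carbon, para to a large group, gives no change at the digits printed from compound 1 to compound 3 (within the scatter) and is the first step in this set that differs in one place. It shows that, on this read-out, this position holds chloro and methyl with no difference beyond the scatter, which compound 1 and compound 2 could not show, as they differ in both the group on the ring and the chain. Compound 3 also carries the same chloro-bearing ring as compound 2, so the longer chain is the one difference between them, and compound 2 gives 6250 nM while compound 3 gives 2500 nM in this assay.

Nothing measured here accounts for these numbers.

The compounds shown leave open how this position would respond to a methoxy group, a trifluoromethyl group or an amine, whether chloro at another place on the ring would read the same, and how chains of intermediate length would fall in this assay on the way to the longer chain of compound 2.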